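The source may hold more compounds than are shown below. What is called first, only, known or untested is meant among the compounds shown, and "the series" means these compounds.

For the measured compounds named here, compound 2 `O=C(CSc1ccc(Cl)cc1)Nc1ccc2nc(NC(=O)c3ccc(F)cc3)sc2c1` gives 1360 nM in a functional assay on HCT-116 cells (Homo sapiens) for antiproliferative activity, read by MTT assay, with a stated time of 72 h (on this read-out higher numbers stand for weaker inhibition and lower numbers for stronger inhibition), and so holds the lower of the two actual numbers so far. Compound 1 `O=C(CSc1cccc(O)c1)Nc1ccc2nc(NC(=O)c3ccc(F)cc3)sc2c1` gives 6170 nM in this assay and stands higher. Compound 3 `O=C(CSc1nnc(NC(=O)COc2ccccc2)s1)Nc1ccc(Br)cc1` sits at > 100000 nM which is a limit and not a number.

The next structure, compound 4 `Cc1ccc(C(=O)Nc2nc3ccc(NC(=O)CSc4ccc(Cl)cc4)cc3s2)cc1` differs from compound 2 by a single swap methyl in place of fluoro on an aromatic carbon that puts methyl in place of fluoro on an aromatic carbon, para to a large group. Going by the values given here, only one measured step is available, and it is a modest one a 4.5-fold lower number from compound 1 to compound 2 (0.66 log units; beyond the scatter) at a different place, on a sulfur. Among the compounds with values here, no measured step therefore tests this swap directly. One heavy atom replaces one heavy atom here, with no change in the counted donors, acceptors or charge, so no shift beyond the scatter is expected. The estimated step is small a 1.1-fold higher number from compound 2 to compound 4 (0.04 log units; within the scatter) and could turn out in either direction. The estimated value for compound 4 is 1500 nM (expected range 550 nM to 4200 nM).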

Compound 4, half-maximal inhibitory concentration: 2120 nM
Estimate against measurement, compound 4: 1.4-fold (0.15 log units) below; the range from low to high includes it.
By their numbers in this assay, from the lowest: compounds 2 and 4 (each within the scatter of the next); then compound 1. At a limit, above all of these: compound 3.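

In this assay, replacing the 4-fluorophenyl with 4-methylphenyl gives a 1.6-fold higher number from compound 2 to compound 4 (0.19 log units; within the scatter) and so, at this place on the ring, fluoro and methyl cannot be told apart. For the compounds shown here, this is the first measured change here, since the only earlier step, a 4.5-fold lower number from compound 1 to compound 2 (0.66 log units; beyond the scatter), lies at a different place, on a sulfur. Going by these compounds alone, nothing measured so far bears on why fluoro and methyl give values within the scatter of each other.

Still open, on these data alone, is whether a group of another kind at this place, such as an amine, a carboxylic acid or a longer chain, would shift the number beyond the scatter. Also open, as far as these compounds go, is whether the same swap would read alike with something other than the 4-chlorophenyl on the sulfur, which compound 2 and compound 4 share.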